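The compounds below may be only part of what the source reports. "The series", "measured", "known", "first", "only" and "open" are said of these compounds alone.

For the measured compounds named here, in an ADME assay on a cell-free system (plasma, Homo sapiens) for protein binding, read by LC-MS, with a stated time of 5 h, tested at 5 uM, two compounds have values so far. Compound 1 `COc1cc(OCc2ccnc(N)c2Cl)cc2sc(N[C@@H]3CCCC[C@H]3O)nc12` gives 98.7% and compound 2 `COc1cc(OCc2ccnc(N)n2)cc2sc(N[C@@H]3CCCC[C@H]3O)nc12` gives 77.1%, so compound 2 stands highest of the two in unbound fraction. Going by the values given here, the one measured step is an 18-fold higher unbound fraction from compound 1 to compound 2 (1.25 log units; beyond the scatter), with 2-aminopyrimidin-4-yl in place of 2-amino-3-chloropyridin-4-yl on a saturated chain carbon bound to an oxygen on an aromatic ring.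

Next is compound 3 `COc1cc(OCc2ccnc(N)n2)cc2sc(N[C@H]3CCCC[C@@H]3O)nc12`, set against compound 2: the two compounds have the same atoms and bonds and differ only in configuration as drawn: 2 of 2 stereo elements differ (all stereocentres are inverted: mirror images); a stereocentre at a saturated ring carbon is drawn R in compound 2 and S in compound 3; a stereocentre at a saturated ring carbon is drawn R in compound 2 and S in compound 3. The measured step exchanged one group for another, while here nothing leaves and nothing enters, so its size does not carry over. Among the compounds with values here, no pair of mirror images has been measured, and the data give no direction for this change. No step beyond the scatter is expected in this assay, and the expectation stays anchored on compound 2 at 77.1%. The estimated step is a 1.0-fold higher unbound fraction from compound 2 to compound 3 (0.00 log units; within the scatter). For compound 3 the expected value is 77%, with an estimated range from 60% to 88%.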

Compound 3, plasma protein binding: 77.6%
Beside the measured number, compound 3's estimate is 1.0-fold (0.01 log units) (unbound fraction) above it; the measured number falls inside the stated range.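

In this assay, for the compounds shown here, inverting both stereocentres at the saturated ring carbons gives a 1.0-fold lower unbound fraction from compound 2 to compound 3 (0.01 log units; within the scatter) and is the first mirror-image comparison. Configuration at these two stereocentres, inverted together, thus leaves the unbound fraction within the scatter with the 2-aminopyrimidin-4-yl group in place, whereas the only earlier step, an 18-fold higher unbound fraction from compound 1 to compound 2 (1.25 log units; beyond the scatter), came from exchanging one group for another on the saturated chain carbon. This pair isolates the stereochemical change, with nothing leaving and nothing entering, so the reading applies to configuration alone: the fact that compounds 2 and 3 differ only in the configuration as drawn.

The compounds shown leave open whether inverting only one of the two stereocentres gives the same reading, and whether the mirror-image change stays within the scatter when the 2-amino-3-chloropyridin-4-yl group, at the much higher binding of compound 1 (98.7%), replaces the 2-aminopyrimidin-4-yl group. They also leave open how this read-out responds when an amine or a carboxylic acid is carried on the saturated ring, since every compound here keeps the same substitution there and differs at most in its configuration.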